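The source may hold more compounds than are shown below. What is called first, only, known or untested is meant among the compounds shown, and "the series" means these compounds.

In a functional assay on HEL cells (Homo sapiens) for cytotoxicity (a lower number here means that less compound is tolerated, a higher number that more compound is tolerated), compound 1 (`CCCCCCCCCCC#Cc1cc2cn([C@@H]3O[C@H](CO)[C@@H](O)[C@@H]3O)c(=O)nc2o1`) gives 116000 nM and compound 2 (`CCCCCCCCC#Cc1cc2cn([C@@H]3O[C@H](CO)[C@@H](O)[C@H]3O)c(=O)nc2o1`) gives 62000 nM. These two numbers lie within the scatter of each other, so compound 2 cannot be separated from compound 1. Compound 3 (`CCCCCCCCC#Cc1cc2cn([C@@H]3O[C@H](CO)[C@@H](O)[C@@H]3O)c(=O)nc2o1`) has the same atoms and bonds as compound 2: the two compounds have the same atoms and bonds and differ only in configuration as drawn: 1 of 4 stereo elements differ; a stereocentre at a saturated ring carbon is drawn R in compound 2 and S in compound 3, and a stereocentre at a saturated ring carbon is drawn R in compound 2 and S in compound 3. Within the data shown here, no measured step shows the effect of such a change, so no shift beyond the scatter is expected in this assay. The estimated 1.2-fold higher number from compound 2 to compound 3 (0.08 log units; within the scatter) has no firm direction. Compound 3 is expected at 75000 nM, with a range of 30000 nM to 190000 nM.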

Compound 3, half-maximal cytotoxic concentration: > 124000 nM
Compound 3 ended at the assay's limit; the forecaster's own chance of this, stated with the estimate: 15%; middle value at least 1.6-fold (0.21 log units) from the limit.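

In this assay compound 3 gives > 124000 nM, which is a limit of the assay and not a number. Among these compounds, the change of configuration at a saturated ring carbon gives an at least 2.0-fold higher number from compound 2 to compound 3 (0.30 log units; that floor lies within the scatter), the only reading so far of such a change, and it shows no shift beyond the scatter. Hydrogen in place of ethyl on a saturated chain carbon gives an at least 1.0-fold higher number from compound 1 to compound 3 (0.02 log units; that floor lies within the scatter), so this chain change shows none either. Open remains whether either step would pass the scatter if compound 3 had a number rather than a limit. Also open, going by these compounds, is how a chain ending in an amine or a carboxylic acid would read in this assay.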